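Adding a Third Methoxy Group to a Trimethoxyphenyl Chalcone

The compounds below may be only part of what the source reports. "The series", "measured", "known", "first", "only" and "open" are said of these compounds alone.

Compound 1, `COc1cc(-c2cc(/C=C/C(=O)c3ccc(N)cc3)[nH]n2)cc(OC)c1OC`: 107%
Compound 2, `COc1ccc(C(=O)/C=C/c2cc(-c3cc(OC)c(OC)c(OC)c3)n[nH]2)cc1OC`: 98%
Compound 3, `COc1ccc(-c2cc(/C=C/C(=O)c3ccc(N)cc3)[nH]n2)cc1OC`: 106%

All three compounds were tested in a functional assay on IGROV-1 cells (Homo sapiens) for cytotoxicity, read by sulforhodamine B assay, with a stated time of 48 h, tested at 0.01 uM; a lower number here means a stronger effect, a higher number a weaker effect of the compound at the concentration tested. At this concentration none of them cuts cell growth to any notable degree; compound 1 gives 107%, which sits at the top of the small group, though every gap here lies within the usual scatter of the measurement.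

Compound 3 and compound 1 differ in one place: methoxy in place of hydrogen on an aromatic carbon. The step of a number 1 percentage points higher from compound 3 to compound 1 (within the scatter) shows that this change made no measurable difference. Compound 1 and compound 2 differ in another way, a 3,4-dimethoxyphenyl in place of a 4-aminophenyl on a carbonyl carbon, and here too the step of a number 9 percentage points lower from compound 1 to compound 2 (within the scatter) stays within the scatter. How the cores of compound 2 and compound 3 differ is not broken down here; their two values simply lie within the scatter of each other.

Compound 4, `COc1cc(C(=O)/C=C/c2cc(-c3cc(OC)c(OC)c(OC)c3)n[nH]2)cc(OC)c1OC`, has not yet been measured. It differs from compound 2 by methoxy in place of hydrogen on an aromatic carbon. The surroundings of the new group are the same, word for word, as in the change from compound 3 to compound 1, so this is the same change. Because the earlier step was a number 1 percentage points higher from compound 3 to compound 1 (within the scatter), the step from compound 2 to compound 4 is expected to be a number 1 percentage points higher from compound 2 to compound 4 (within the scatter), again within the scatter. Compound 4 is therefore estimated at 99%, with a likely range from 88% to 110%.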

Compound 4, a percentage reported as activity, at one concentration (the size of the read-out at that concentration, not a potency): 104%
For compound 4 the middle estimate is 5 percentage points below the measured one; low and high end bracket the measured number.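

The new step, a number 6 percentage points higher from compound 2 to compound 4 (within the scatter), is the second reading of the same change, a methoxy group in place of hydrogen on an aromatic carbon, in this assay. Set beside the first reading, the change looks the same on both cores, as far as this test can tell: the same change on two cores in this assay, a number 1 percentage points higher (within the scatter) from compound 3 to compound 1 and a number 6 percentage points higher (within the scatter) from compound 2 to compound 4, 5 percentage points apart, within the scatter of two such steps. For the compounds shown here, this agreement is weak evidence, however: neither step can be told apart from the noise, so the pair shows only that the extra methoxy group had no detectable effect on either core at this one low concentration, and it does not show that the change would carry over in the same way under conditions where these compounds clearly reduce cell growth.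

The compounds shown leave open how the same change would behave at higher concentrations, where a real effect might be large enough to compare, and on cores other than these two. They also leave open whether a hydroxyl group, a chlorine atom or a longer chain such as ethoxy, placed where the new methoxy group sits, would give a step of similar size.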